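The compounds below may be only part of what the source reports. "The series", "measured", "known", "first", "only" and "open" are said of these compounds alone.

Measured values in an assay on membranes from HEK293 cells for displacement of a labelled ligand from adenosine receptor A2b (Homo sapiens), read by scintillation counting, with a stated time of 30 min, tested at 1 uM; on this read-out higher numbers stand for more inhibition at the one concentration tested (going by the name of the read-out) and lower numbers for less inhibition:
- compound 1 `CC1=C(C(=O)OCC(C)C)C(c2ccco2)NC(=O)N1C`: 4%
- compound 2 `COC(=O)C1=C(C)N(C)C(=O)NC1c1cccs1`: 17%
- compound 3 `CCCOC(=O)C1=C(C)N(C)C(=O)NC1c1cccs1`: 1%

Compound 3 gives the lowest of the three numbers; compound 1 sits within the scatter of it, while compound 2 lies beyond the scatter above it. Going by the values given here, the single measured step, a number 16 percentage points lower from compound 2 to compound 3 (beyond the scatter), accompanies ethyl in place of hydrogen on a saturated chain carbon bound to an oxygen next to a carbonyl group.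

Compound 4 `CC1=C(C(=O)OCC(C)C)C(c2cccs2)NC(=O)N1C` differs from compound 3 by methyl in place of hydrogen on a saturated chain carbon bound to two saturated chain carbons. Among the compounds with values here, no measured step covers this branching directly. Lengthening the same chain gave the drop from compound 2 to compound 3, and compound 1, which carries the same isobutyl group on its own core, gives 4%. For compound 4 no step beyond the scatter is therefore expected, a number 2 percentage points higher from compound 3 to compound 4 (within the scatter). Compound 4 is estimated at 3%, between 0% and 12%.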

Compound 4, a percentage reported as inhibition, at one concentration (the size of the read-out at that concentration, not a potency): 2%
Compound 4: the middle estimate sits 1 percentage points above what was measured; low and high end bracket the measured number.
By their numbers in this assay, from the lowest: compounds 3, 4 and 1 (each within the scatter of the next); then compound 2.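

In this assay, propoxy to isobutoxy, with methyl in place of hydrogen on a saturated chain carbon bound to two saturated chain carbons, gives (a number 1 percentage points higher from compound 3 to compound 4 (within the scatter)), so this branching leaves the number unchanged within the scatter. Thiophen-2-yl in place of furan-2-yl on a saturated ring carbon gives (a number 2 percentage points lower from compound 1 to compound 4 (within the scatter)), and isopropyl in place of hydrogen gives (a number 15 percentage points lower from compound 2 to compound 4 (beyond the scatter)), so the shift from compound 2 also holds for the branched chain. No evidence on the cause of these steps is available.

Still open, from the compounds shown here alone, is whether an amine or a carboxylic acid in place of isobutoxy, or phenyl in place of thiophen-2-yl, would give a number above that of compound 2 (17%).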